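The compounds below may be only part of what the source reports. "The series", "measured", "known", "first", "only" and "open" are said of these compounds alone.

Among the three compounds measured in an assay on membranes from Sf9 cells for displacement of a labelled ligand from histamine H2 receptor (Homo sapiens), read by scintillation counting, with a stated time of 60 min (on this read-out lower numbers stand for stronger inhibition and higher numbers for weaker inhibition), compound 2 `Cc1nc(N)sc1CCCN/C(N)=N/C(=O)NC(C)c1ccccc1F` gives 28.8 nM, the lowest number of the set. Compound 3 `CCCCCCNC(=O)/N=C(\N)NC1CCc2nc(N)sc2C1` gives 1120 nM, and compound 1 `CCCNC(=O)/N=C(\N)Nc1cccc(-c2csc(N)n2)c1` gives 5250 nM; the gaps from compound 2 to each of these lie beyond the usual scatter. Compound 4 `Cc1nc(N)sc1CCCN/C(N)=N/C(=O)NC(C)c1ccco1` has not yet been measured in this assay. It differs from compound 2 in one place: furan-2-yl in place of 2-fluorophenyl on a saturated chain carbon bound to an amide-type nitrogen and a saturated chain carbon. For the measured compounds named here, no pair of measured compounds differs in only one place, so the size of such a step cannot be read from the measured data. In this assay the expected step is a 2.1-fold higher number from compound 2 to compound 4 (0.32 log units; beyond the scatter), a small shift toward weaker inhibition, if any beyond the scatter. Compound 4 is accordingly estimated at 60 nM, with a range from 15 nM to 250 nM.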

Compound 4, inhibition constant: 31.6 nM
Compound 4: middle estimate off by 1.9-fold (0.28 log units), on the high side, and the stated range covers the measured number.
By their numbers in this assay, from the lowest: compounds 2 and 4 (each within the scatter of the next); then compound 3; then compound 1.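

In this assay, for the compounds shown here, the exchange of 2-fluorophenyl for furan-2-yl gives a 1.1-fold higher number from compound 2 to compound 4 (0.04 log units; within the scatter) and is the first step at one place that can be read in this set. At this saturated chain carbon, then, a six-membered aromatic ring of carbon only and a five-membered aromatic ring with 1 hetero atom serve alike in this assay. Nothing at hand bears on the reason for this. The compounds shown leave open whether a cyclohexyl ring or a carboxylic acid on that carbon would hold the number at this level. They also leave open whether the same exchange would give a like step on the cores of compound 1 and compound 3.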